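The compounds below may be only part of what the source reports. "The series", "measured", "known", "first", "only" and "open" are said of these compounds alone.

Compound 1 `CC1CCCCC1N(CCCCCCN1C[C@H](O)[C@@H](O)[C@H](O)[C@H]1CO)C(=O)C(C)(C)C` gives > 500000 nM in an ADME assay on BHK cells (Mesocricetus auratus) for cytotoxicity, read by MTT assay (a lower number here means that less compound is tolerated, a higher number that more compound is tolerated), which is a limit of the assay rather than a number.
Compound 2 `CC(C)(C)C(=O)N(CCCCCCN1C[C@H](O)[C@@H](O)[C@H](O)[C@H]1CO)c1cc(F)ccc1F` gives > 500000 nM in this assay, again a limit rather than a number.

Compound 2 thus stands only at a limit in this assay. Going by the values given here, the one measured step, a step that the two limits leave unreadable from compound 1 to compound 2, cannot be sized because both values sit at the limit of > 500000 nM in this assay, at which 2 of the 2 values shown sit. Compound 3 `CC(C)(C)C(=O)N(CCCCCCN1C[C@H](O)[C@@H](O)[C@H](O)[C@H]1CO)C1CCC1` differs from compound 2 by cyclobutyl in place of 2,5-difluorophenyl on an amide-type nitrogen. Among the compounds with values here, no measured step can guide this change, so no shift beyond the scatter is expected, and compound 3 is estimated at a step of a number no higher from compound 2 to compound 3 (the limit leaves the size open). Compound 3 is therefore expected to give about 500000 nM, within 200000 nM to 1000000 nM, most likely again reported only as a limit.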

Compound 3, half-maximal cytotoxic concentration: > 500000 nM
Compound 3 gave a limit, no number (the forecaster's own chance of this, stated with the estimate: 80%); the middle value lies on the limit itself.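

No step can be read among compound 1, compound 2 and compound 3, because all three values are limits and not numbers: the limit of > 500000 nM in this assay, at which 3 of the 3 values shown sit. The compounds shown leave open how much of each compound is tolerated in this assay and whether the group on the amide-type nitrogen alters it.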